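Swapping an Aryl Group for an Octyl Chain

The source may report more compounds than this note shows. Statements on the series, on what has been measured and on what is new or still open speak of the compounds shown alone.

Measured compounds:
Compound 1, `CC(C)(C)c1ccc(-c2cc(-c3cn([C@H]4C[C@H](O)[C@@H](CO)O4)c(=O)[nH]c3=O)on2)cc1`: 102%
Compound 2, `CC(=O)OC[C@H]1O[C@@H](n2cc(-c3cc(-c4ccc(C(C)C)cc4)no3)c(=O)[nH]c2=O)C[C@@H]1OC(C)=O`: 83.2%
Compound 3, `O=c1[nH]c(=O)n([C@H]2C[C@H](O)[C@@H](CO)O2)cc1-c1cn(Cc2ccccc2)nn1`: 103%

In a functional assay on MDA-MB-231 cells (Homo sapiens) for cytotoxicity, read by sulforhodamine B assay, tested at 10 uM (on this read-out higher numbers stand for more inhibition at the one concentration tested (going by the name of the read-out) and lower numbers for less inhibition), compound 1 gives 102%, the second highest of the three numbers recorded. Compound 3 gives 103%, a number within the usual scatter of the value of compound 1, so the two cannot be told apart on this read-out. Compound 2 gives 83.2%, which lies beyond the scatter below compound 1. Among the compounds with values here, because no pair of these measured compounds differs in just one place, the data offer no isolated step from which to judge how a single change shifts the read-out.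

Compound 4, `CCCCCCCCc1cc(-c2cn([C@H]3C[C@H](O)[C@@H](CO)O3)c(=O)[nH]c2=O)on1`, differs from compound 1 in one place: octyl in place of 4-(tert-butyl)phenyl on an aromatic carbon. All three measured compounds show strong inhibition in this assay, and the shared core stays untouched in compound 4. The step from compound 1 to compound 4 is therefore expected to be small, a number 12 percentage points lower from compound 1 to compound 4 (beyond the scatter), if anything a slight drop. Compound 4 is estimated at 90%, with a range of 60% to 105%.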

Compound 4, a percentage reported as inhibition, at one concentration (the size of the read-out at that concentration, not a potency): 96.7%
Beside the measured number, compound 4's estimate is 6.7 percentage points below it; the range from low to high includes it.
By their numbers in this assay, from the lowest: compound 2; then compounds 4, 1 and 3 (each within the scatter of the next).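

In this assay, within the data shown here, the change gives a number 5.3 percentage points lower from compound 1 to compound 4 (within the scatter), the first step that isolates a single position. On this aromatic carbon, next to the ring nitrogen, the read-out at the one concentration tested does not depend on a six-membered aromatic ring: an octyl chain with no ring cannot be told apart from 4-(tert-butyl)phenyl. No measurement here speaks to why the two groups read alike.

A single concentration gives the size of the effect rather than a potency, so compounds that read alike here could still separate at lower concentrations. As far as these compounds go, it also remains open how this carbon would respond to a much shorter chain such as methyl, or to an octyl chain ending in an amine or a carboxylic acid.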